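Chloro position on the aryl group of compound 3

The source may report more compounds than this note shows. Statements on the series, on what has been measured and on what is new or still open speak of the compounds shown alone.

Measured so far in a functional assay on the whole organism (strain C57B/6) with Mus musculus as the target, in the maximal electroshock model; on this read-out higher numbers stand for an effect only at larger amounts of compound and lower numbers for an effect already at smaller amounts:
- compound 1 `CCCCCCOc1ccc(-n2cnnc2CCCCCC)cc1`; in this assay compound 1 reaches only the assay limit, > 40 mg/kg.
- compound 2 `CCCCCCOc1ccc(-n2cnnc2-c2ccccc2)cc1`; compound 2 gives 19 mg/kg.
- compound 3 `CCCCCCOc1ccc(-n2cnnc2-c2ccc(Cl)cc2)cc1`; compound 3 gives 19.7 mg/kg.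

Compound 3 holds the higher of the two numbers, yet compound 2 sits within the scatter of it (a 1.0-fold higher number from compound 2 to compound 3 (0.02 log units; within the scatter)); compound 1 stands at a limit (the limit of > 40 mg/kg in this assay, at which 1 of the 3 values shown sits). Compound 4 `CCCCCCOc1ccc(-n2cnnc2-c2ccccc2Cl)cc1` differs from compound 3 by 2-chlorophenyl in place of 4-chlorophenyl on an aromatic carbon. Among the measured compounds shown here, the only step that changes substitution on that aryl group is a 1.0-fold higher number from compound 2 to compound 3 (0.02 log units; within the scatter), within the scatter; the steps of an at least 2.1-fold lower number from compound 1 to compound 2 (0.32 log units; beyond the scatter) and an at least 2.0-fold lower number from compound 1 to compound 3 (0.30 log units; that floor lies within the scatter) exchange the whole group and do not bear on where the chlorine sits. No step beyond the scatter is therefore expected, a 1.0-fold higher number from compound 3 to compound 4 (0.01 log units; within the scatter). Compound 4 is estimated at 20 mg/kg, between 10 mg/kg and 40 mg/kg.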

Compound 4, dose for half-maximal effect: 13.2 mg/kg
Compound 4: middle estimate off by 1.5-fold (0.18 log units), on the high side; low and high end bracket the measured number.
By their numbers in this assay, from the lowest: compounds 4, 2 and 3 (each within the scatter of the next). At a limit, above all of these: compound 1.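

In this assay, 2-chlorophenyl in place of 4-chlorophenyl gives a 1.5-fold lower number from compound 3 to compound 4 (0.17 log units; within the scatter), and chloro in place of hydrogen gives a 1.4-fold lower number from compound 2 to compound 4 (0.16 log units; within the scatter), so the two chlorine placements and the unsubstituted phenyl are not separated on this read-out. 2-Chlorophenyl in place of hexyl gives an at least 3.0-fold lower number from compound 1 to compound 4 (0.48 log units; beyond the scatter), a floor that clears the scatter, which the floor for 4-chlorophenyl did not. That floor rests on a limit for compound 1, not a number: the limit of > 40 mg/kg in this assay, at which 1 of the 4 values shown sits.

As far as these compounds go, whether an amine or a methoxy group in place of chloro on this aryl group would give a step beyond the scatter stays open.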